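Para-substituted phenyl oxazoles: hydroxy to chloro step

The source may report more compounds than this note shows. Statements on the series, on what has been measured and on what is new or still open speak of the compounds shown alone.

Measured so far: compound 1 `Cc1nc(-c2c[nH]c3ccccc23)co1` with 316000 nM; compound 2 `Fc1ccc(-c2nc(-c3c[nH]c4ccccc34)co2)cc1` with 59800 nM; compound 3 `Oc1ccc(-c2nc(-c3c[nH]c4ccccc34)co2)cc1` with 449000 nM, all in a functional assay on LNCaP cells (Homo sapiens) for cytotoxicity, read by MTT assay, with a stated time of 48 h; a lower number here means a stronger inhibitor, a higher number a weaker inhibitor.

Compound 3 carries the highest number of the three; against compound 1 the gap is a 1.4-fold higher number from compound 1 to compound 3 (0.15 log units; within the scatter), and against compound 2 it is a 7.5-fold higher number from compound 2 to compound 3 (0.88 log units; beyond the scatter). Compound 4 `Clc1ccc(-c2nc(-c3c[nH]c4ccccc34)co2)cc1` differs from compound 3 by chloro in place of hydroxy on an aromatic carbon. Among the compounds with values here, no measured step swaps hydroxy for chloro at this position. The nearest guide is the hydroxy-for-fluoro step, a 7.5-fold higher number from compound 2 to compound 3 (0.88 log units; beyond the scatter), which compound 4 runs in the opposite sense, so a lower number is expected, roughly a 5.6-fold lower number from compound 3 to compound 4 (0.75 log units; beyond the scatter). Compound 4 is therefore estimated at 80000 nM, within 20000 nM to 300000 nM.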

Compound 4, half-maximal inhibitory concentration: 505000 nM
Compound 4: middle estimate off by 6.3-fold (0.80 log units), on the low side; the measured number lies above the stated range.
By their numbers in this assay, from the lowest: compound 2; then compounds 1, 3 and 4 (each within the scatter of the next).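

At the position para to a large group, chloro does not follow fluoro in this assay: the change runs to an 8.4-fold higher number from compound 2 to compound 4 (0.93 log units; beyond the scatter) and sets compound 2 apart, while hydroxy and chloro cannot be told apart, with a 1.1-fold higher number from compound 3 to compound 4 (0.05 log units; within the scatter) on that swap. Compound 4 also stays level with the methyl-bearing compound 1, as a 1.6-fold higher number from compound 1 to compound 4 (0.20 log units; within the scatter) shows, so among the aryl groups here only 4-fluorophenyl separates from methyl. No available evidence accounts for fluoro and chloro parting here.

Open, on these data alone, is whether an amine, a methoxy group or a carboxylic acid at this position would stand with fluoro or with chloro and hydroxy.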